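Para-substituted aryl series: methyl for methylsulfanyl

The compounds below may be only part of what the source reports. "The series", "measured", "known", "first", "only" and "open" are said of these compounds alone.

Three compounds of the shared core carry a measurement in an assay for binding affinity to adenosine receptor A1 (Bos taurus); on this read-out lower numbers stand for stronger inhibition and higher numbers for weaker inhibition. Compound 1 `CSc1ccc(-c2nc3c(=O)n(C)c(=O)n(C)c3[nH]2)cc1` gives 2 nM in this assay. Compound 2 `C=CCn1c(=O)c2[nH]c(-c3ccccc3)nc2n(C)c1=O` gives 4 nM, and compound 3 `Cn1c(=O)c2nc(-c3cccc(N)c3)[nH]c2n(C)c1=O` gives 10 nM. Compound 1 sits at the low end of these numbers; its gap to compound 2 lies within the usual scatter of this assay, while its gap to compound 3 lies beyond it. For the measured compounds named here, no pair among the measured compounds differs in a single place, so no measured step is available for this read-out.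

Compound 4 `Cc1ccc(-c2nc3c(=O)n(C)c(=O)n(C)c3[nH]2)cc1` is not yet measured. It differs from compound 1 by methyl in place of methylsulfanyl on an aromatic carbon. With no measured step of this kind in the series, the size and direction of the change cannot be anchored on data; a modest step toward a higher number, of a size near the scatter, is expected. The step from compound 1 to compound 4 is estimated at a 2.0-fold higher number from compound 1 to compound 4 (0.30 log units; within the scatter). Compound 4 is expected to give about 4 nM in this assay, within a range of 1.5 nM to 12 nM.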

Compound 4, half-maximal inhibitory concentration: 0.8 nM
For compound 4 the middle estimate is 5.0-fold (0.70 log units) above the measured one, outside the stated range (below it).
By their numbers in this assay, from the lowest: compound 4; then compounds 1 and 2 (each within the scatter of the next); then compound 3.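

For the compounds shown here, this is the first measured single-place step: at this aromatic carbon, methyl in place of methylsulfanyl gives a 2.5-fold lower number from compound 1 to compound 4 (0.40 log units; beyond the scatter) in this assay. The step is modest but beyond the scatter, so the sulfur and the hydrogen-bond acceptor counted for methylsulfanyl are not required here for a low number in this assay. Nothing available accounts for the direction of this step.

From the compounds shown here alone, it remains open whether a longer chain such as ethyl, a chlorine atom, a hydroxyl group or a carboxylic acid on this same aromatic carbon would lower the number further or raise it. A single pair also leaves open whether methyl in place of methylsulfanyl would give a step of similar size and direction elsewhere on the six-membered ring.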